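Replacing a basic side chain with a tertiary alcohol

The source may hold more compounds than are shown below. What is called first, only, known or untested is meant among the compounds shown, and "the series" means these compounds.

Compound 1 `COCCOCC1CN(c2ccccc2)NC1=O` gives 520 nM in an assay on isolated protein for inhibition of Polyunsaturated fatty acid 5-lipoxygenase (Rattus norvegicus); on this read-out lower numbers stand for stronger inhibition and higher numbers for weaker inhibition. For compound 2 `CN(C)CCC1CN(c2ccccc2)NC1=O` this assay returns only a limit, > 1000 nM. Among the measured compounds shown here, the single measured step, an at least 1.9-fold higher number from compound 1 to compound 2 (0.28 log units; that floor lies within the scatter), therefore rests on one value that is a limit, as noted at the limit of > 1000 nM in this assay, at which 1 of the 2 values shown sits. Compound 3 `CC(C)(O)C1CN(c2ccccc2)NC1=O` differs from compound 2 by 1-hydroxy-1-methylethyl in place of 2-(dimethylamino)ethyl on a saturated ring carbon. For the measured compounds named here, no measured step shares this change, and compound 2 stands at the limit, so the direction cannot be gauged from the data; the expected step is a step that the limit leaves unreadable from compound 2 to compound 3. Compound 3 is estimated at 1500 nM, with a range from 400 nM to 6000 nM.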

Compound 3, half-maximal inhibitory concentration: > 1000 nM
Compound 3: no number, only a limit (the forecaster's own chance of this, stated with the estimate: 55%); the middle value lies beyond the limit too.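

In this assay compound 3, with 1-hydroxy-1-methylethyl on the saturated ring carbon, returns only a limit, so neither it nor compound 2 gives a number and the step between them cannot be read. With (2-methoxyethoxy)methyl replaced at this place, the change gives an at least 1.9-fold higher number from compound 1 to compound 3 (0.28 log units; that floor lies within the scatter). Two different groups at this place now end at the same limit, and only compound 1 gives a number: the limit of > 1000 nM in this assay, at which 2 of the 3 values shown sit.

Going by these compounds, how far compound 2 and compound 3 lie past that limit stays open. So does how a carboxylic acid or a longer ether chain at this place would read in this assay.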